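Moving the basic nitrogen: piperazine to piperidine

This account rests on a few compounds, and the source may have more. Where it says the series, first, only, none or still open, it means among the compounds named here.

Measured so far:
compound 1 `c1ccc2c(c1)CN[C@@H](CN(CCCN1CCNCC1)[C@H]1CCCc3cccnc31)C2` gives 17 nM in a functional assay on CCRF-CEM cells for antagonist activity at C-X-C chemokine receptor type 4 (Homo sapiens), read by calcium flux, with stated times of 25 min and 90 s; on this read-out higher numbers stand for weaker inhibition and lower numbers for stronger inhibition;
compound 2 `c1ccc2c(c1)CN[C@@H](CN(CCC1CCNCC1)[C@H]1CCCc3cccnc31)C2` gives 150 nM in this assay;
compound 3 `c1ccc2c(c1)CN[C@@H](CN(CCN1CCNCC1)[C@H]1CCCc3cccnc31)C2` gives 553 nM in this assay.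

Compound 3 gives the highest number of the three. Its nearest neighbour is compound 2, and the step of a 3.7-fold higher number from compound 2 to compound 3 (0.57 log units; beyond the scatter) lies beyond the scatter; the step of a 33-fold higher number from compound 1 to compound 3 (1.51 log units; beyond the scatter) is larger still. The measured step of an 8.8-fold higher number from compound 1 to compound 2 (0.95 log units; beyond the scatter) shows that shortening the link to the basic ring and exchanging the piperazine for a piperidine is not neutral either.

Compound 4 `c1ccc2c(c1)CN[C@@H](CN(CC[C@H]1CCCNC1)[C@H]1CCCc3cccnc31)C2` is the unmeasured compound. It differs from compound 3 in one place: piperidin-3-yl in place of piperazin-1-yl on a saturated chain carbon, two bonds along the chain from an amine nitrogen. The step that bears most directly on this change is a 3.7-fold higher number from compound 2 to compound 3 (0.57 log units; beyond the scatter), in which a piperazin-1-yl took the place of a piperidin-4-yl at the same position and the number went up. Compound 4 carries a piperidine again, attached through a ring carbon rather than the ring nitrogen, so the reverse of that step is the natural expectation: a modest move toward a lower number, back toward the value of compound 2. Among the measured compounds shown here, no measured pair shows a piperidin-3-yl, so the precise size is uncertain.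

For compound 4 the expected step is a 3.1-fold lower number from compound 3 to compound 4 (0.49 log units; beyond the scatter), giving an estimate of 180 nM with a range from 60 nM to 550 nM.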

Compound 4, half-maximal inhibitory concentration: 16 nM
Estimate against measurement, compound 4: 11-fold (1.05 log units) above; the whole stated range lies above it.
By their numbers in this assay, from the lowest: compounds 4 and 1 (each within the scatter of the next); then compound 2; then compound 3.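

In this assay, the place on a saturated chain carbon, two bonds along the chain from an amine nitrogen, proves sensitive to where a piperidine ring is attached: moving from piperidin-4-yl to piperidin-3-yl gives a 9.4-fold lower number from compound 2 to compound 4 (0.97 log units; beyond the scatter) and lies beyond the scatter, so compound 2 cannot stand for piperidines in general. The exchange of piperazin-1-yl for piperidin-3-yl is thus much more than a return to the value of compound 2, as a 35-fold lower number from compound 3 to compound 4 (1.54 log units; beyond the scatter) shows that this single change covers the large gap first seen with the (piperazin-1-yl)methyl group. That group and piperidin-3-yl cannot be told apart on these numbers, since a 1.1-fold lower number from compound 1 to compound 4 (0.03 log units; within the scatter) places the two compounds within the scatter of each other, and a ring with one hetero atom therefore serves here as well as the (piperazin-1-yl)methyl group.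

The data shown offer no independent measurement that accounts for the difference between the two piperidine attachments. They also leave open how the opposite stereoisomer of the piperidin-3-yl group, a piperidin-2-yl group or a pyrrolidin-3-yl group would behave at this place.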